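The compounds below may be only part of what the source reports. "The series", "measured", "known", "first", "only" and "open" are said of these compounds alone.

The measured compounds:
Compound 1, `Cc1ccc(CN2CCC(NC(=O)NCc3ccc(-c4ccc(F)cc4)cc3)CC2)cc1`: in an in vitro functional assay on HEK293 cells for antagonist activity at melanin-concentrating hormone receptor 1 (Homo sapiens), read by GTPgammaS binding, with a stated time of 45 min (a higher number here means a weaker inhibitor, a lower number a stronger inhibitor), compound 1 gives 198 nM.
Compound 2, `Cc1ccc(CN2CCC(CCN(Cc3ccc(-c4cccc(C#N)c4)cc3)C(=O)NC(C)C)CC2)cc1`: in this assay compound 2 gives 1010 nM.
Compound 3, `Cc1ccc(CN2CCC(CCN(Cc3ccc(-c4ccccc4)cc3)C(=O)NC(C)C)CC2)cc1`: in this assay compound 3 gives 220 nM.

Compound 3 has the second highest of the three numbers. Its nearest neighbour is compound 1, whose value lies within the usual scatter of it, so no order between the two can be claimed. For the measured compounds named here, the only single-point step among the measured compounds is a 4.6-fold lower number from compound 2 to compound 3 (0.66 log units; beyond the scatter), which concerns a cyano on an aromatic carbon.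

Compound 4, `CC(=O)OCC(C)(C)NC(=O)N(CCC1CCN(Cc2ccc(C)cc2)CC1)Cc1ccc(-c2ccccc2)cc1`, differs from compound 3 by acetoxymethyl in place of hydrogen on a saturated chain carbon bound to an amide-type nitrogen and two saturated chain carbons. Going by the values given here, that change sits at the urea terminus, a place untouched by the one measured step, and compound 1 differs from compound 3 in more than one place, so only its value can be set beside that of compound 3. Among the compounds with values here, no measured step therefore bears on this change, and compound 4 is expected to show a step of a 1.2-fold higher number from compound 3 to compound 4 (0.07 log units; within the scatter), not beyond the scatter. For compound 4 the estimated value in this assay is 260 nM, with a range from 90 nM to 800 nM.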

Compound 4, antagonist equilibrium constant: 366 nM
Beside the measured number, compound 4's estimate is 1.4-fold (0.15 log units) below it, and the stated range covers the measured number.
By their numbers in this assay, from the lowest: compounds 1, 3 and 4 (each within the scatter of the next); then compound 2.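

In this assay, for the compounds shown here, the change to acetoxymethyl gives the first measured step at this saturated chain carbon bound to an amide-type nitrogen and two saturated chain carbons (a 1.7-fold higher number from compound 3 to compound 4 (0.22 log units; within the scatter)). Turning isopropyl into 1-(acetoxymethyl)-1-methylethyl adds 5 heavy atoms, yet compound 3 and compound 4 cannot be told apart here, so this place accepts a substantially larger group without a shift that can be read beyond the scatter. No available evidence bears on why this is so.

On these data alone, whether a hydroxymethyl group, a carboxylic acid or a primary amine at this carbon would behave the same remains open. Also open, as far as these compounds go, is whether acetoxymethyl would have the same outcome in the nitrile-bearing compound 2 or in the shorter urea of compound 1.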